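A few compounds are considered here, and "the series" means these few. Any claim that something is new, unique, unknown or untested is made for them only; others in the source may bear on it.

Measured in an ADME assay on MRC5 cells (Homo sapiens) for cytotoxicity, read by fluorescence, with a stated time of 72 h; on this read-out higher numbers stand for weaker inhibition and lower numbers for stronger inhibition:
- compound 1 `CC1(COc2ccc(OC(F)(F)F)cc2)Cn2ccnc2O1`: > 64000 nM, a limit of the assay
- compound 2 `CC1(COc2ccc(OC(F)(F)F)cc2)Cn2cc(Br)nc2O1`: 34000 nM
- compound 3 `CSc1cn2c(n1)OC(C)(COc1ccc(OC(F)(F)F)cc1)C2`: 38000 nM

Compound 3 has one exact number to compare with, and that gap lies within the scatter: a 1.1-fold higher number from compound 2 to compound 3 (0.05 log units; within the scatter). Compound 4 `CC1(COc2ccc(OC(F)(F)F)cc2)Cn2cc(S(C)(=O)=O)nc2O1` carries methylsulfonyl in place of methylsulfanyl on an aromatic carbon. The other measured replacements at this carbon are an at least 1.8-fold lower number from compound 1 to compound 2 (0.27 log units; that floor lies within the scatter) and an at least 1.6-fold lower number from compound 1 to compound 3 (0.22 log units; that floor lies within the scatter). Both rest on a limit, and neither floor exceeds the scatter. No step beyond the scatter is therefore expected in this assay. The estimated change is a 1.1-fold higher number from compound 3 to compound 4 (0.02 log units; within the scatter). For compound 4 the expected value is 40000 nM, with an estimated range of 20000 nM to 64000 nM.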

Compound 4, half-maximal inhibitory concentration: > 64000 nM
Compound 4 was reported as a limit (the forecaster's own chance of this, stated with the estimate: 35%); at least 1.6-fold (0.20 log units) between middle value and limit.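

In this assay compound 4 gives > 64000 nM, which is a limit of the assay. Methylsulfonyl thus joins the hydrogen of compound 1 at that limit, whereas bromo and methylsulfanyl give exact numbers, with an at least 1.6-fold higher number from compound 3 to compound 4 (0.22 log units; that floor lies within the scatter) and an at least 1.8-fold higher number from compound 2 to compound 4 (0.27 log units; that floor lies within the scatter); the step between the two limit compounds cannot be read. Both readable steps are only floors, and the limit is shared: the limit of > 64000 nM in this assay, at which 2 of the 4 values shown sit.

The compounds shown leave open whether compound 1 and compound 4 differ at all. They also leave open whether an amine or a carboxylic acid at this carbon would give an exact number or the same limit.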